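Phenyl in place of (3-(trifluoromethyl)phenyl)amino on a carbonyl carbon

This account rests on a few compounds, and the source may have more. Where it says the series, first, only, none or still open, it means among the compounds named here.

In a functional assay on OVCAR-8 cells (Homo sapiens) for inhibition, read by sulforhodamine B assay, with a stated time of 48 h (on this read-out higher numbers stand for weaker inhibition of growth and lower numbers for stronger inhibition of growth), compound 1 (`O=C(Nc1cccc(-n2cc(-c3ccncc3)c(-c3ccc(Cl)c(O)c3)n2)c1)Nc1cccc(C(F)(F)F)c1`) gives no number, only the limit > 32500 nM of the assay. Compound 2 (`COc1cc(-c2nn(-c3cccc(NC(=O)Nc4ccc(Cl)c(Cl)c4)c3)cc2-c2ccncc2)ccc1Cl`) gives 3610 nM and compound 3 (`COc1cc(-c2nn(-c3cccc(NC(=O)Nc4cccc(C(F)(F)F)c4)c3)cc2-c2ccncc2)ccc1Cl`) gives 2700 nM and these two values lie within the scatter of each other, so compound 3 stands level with compound 2 at the low end of the numbers shown.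

Compound 4 (`COc1cc(-c2nn(-c3cccc(NC(=O)c4ccccc4)c3)cc2-c2ccncc2)ccc1Cl`) differs from compound 3 in one place: phenyl in place of (3-(trifluoromethyl)phenyl)amino on a carbonyl carbon and the change is phenyl in place of (3-(trifluoromethyl)phenyl)amino on a carbonyl carbon. For the measured compounds named here, no measured step covers this change directly. Replacing 3,4-dichlorophenyl with 3-(trifluoromethyl)phenyl on an amide-type nitrogen gave a 1.3-fold lower number from compound 2 to compound 3 (0.13 log units; within the scatter) and so the aryl group there has mattered little so far. Elsewhere in the molecule, methyl in place of hydrogen on an oxygen on an aromatic ring gave an at least 12-fold lower number from compound 1 to compound 3 (1.08 log units; beyond the scatter) and this shows that a single change in the series can be large. A moderate move to a higher number is therefore expected, with a 2.2-fold higher number from compound 3 to compound 4 (0.35 log units; beyond the scatter) as the estimated step. In this assay compound 4 is expected at 6000 nM with a range of 2200 nM to 25000 nM as the estimate.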

Compound 4, concentration for total growth inhibition: > 100000 nM
Compound 4 was reported as a limit (the forecaster's own chance of this, stated with the estimate: 20%); middle value at least 16-fold (1.22 log units) from the limit.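

In this assay, exchanging one aryl group for another on the amide-type nitrogen had left the values within the scatter, but replacing the whole arylamino group on the carbonyl carbon with phenyl gives an at least 37-fold higher number from compound 3 to compound 4 (1.56 log units; beyond the scatter), and likewise an at least 27-fold higher number from compound 2 to compound 4 (1.44 log units; beyond the scatter). The tolerance seen at this position therefore covers a swap of the substituted phenyl group, but does not extend to this larger change, which removes the amino nitrogen and the ring substituents together. The result for compound 4 is a limit of the assay and not a number: the limit of > 100000 nM in this assay, at which 1 of the 4 values shown sits.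

The compounds shown leave open whether the loss follows the amino nitrogen with its hydrogen or the trifluoromethyl group. A plain phenylamino group on the carbonyl carbon, or a 3-(trifluoromethyl)phenyl group directly on it, would separate the two.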